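Fluoro shift on the indolyl group of compound 1

The compounds below may be only part of what the source reports. "The series", "measured", "known", "first", "only" and "open" are said of these compounds alone.

In a functional assay on HCT-116 cells (Homo sapiens) for antiproliferative activity, with a stated time of 72 h (a higher number here means a weaker inhibitor, a lower number a stronger inhibitor), compound 1 (`O=C(COc1ccc(CN2CC=C(c3c[nH]c4cccc(F)c34)CC2)c(F)c1)NO`) gives 1220 nM. Compound 3 (`O=C(COc1ccc(CN2CC=C(c3c[nH]c4cccc(F)c34)CC2)cc1)NO`) gives 969 nM, and the two cannot be separated: a 1.3-fold lower number from compound 1 to compound 3 (0.10 log units; within the scatter). Within the data shown here, compound 2 (`O=C(COc1ccc(CNCCn2cnc3ccccc32)c(F)c1)NO`) gives 410 nM, a number clearly lower than that of compound 1, but it differs from compound 1 in more than one place and offers no clean step.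

Compound 4 (`O=C(COc1ccc(CN2CC=C(c3c[nH]c4ccc(F)cc34)CC2)c(F)c1)NO`) has the same atoms as compound 1, joined differently: 5-fluoro-1H-indol-3-yl in place of 4-fluoro-1H-indol-3-yl on a double-bonded ring carbon. The change is 5-fluoro-1H-indol-3-yl in place of 4-fluoro-1H-indol-3-yl on a double-bonded ring carbon of a six-membered non-aromatic ring with 1 nitrogen.

Among the measured compounds shown here, no measured step tests this place directly. The nearest evidence is compound 3, where hydrogen in place of fluoro on an aromatic carbon elsewhere in the molecule gave a 1.3-fold lower number from compound 1 to compound 3 (0.10 log units; within the scatter). That is one step only, so it supports a modest expectation and no trend. Removing a fluoro there left the number within the scatter, so relocating one on the indolyl group is not expected to do more. The expected result is a 1.2-fold lower number from compound 1 to compound 4 (0.07 log units; within the scatter), which is no change beyond the scatter. For compound 4 the estimated value is 1050 nM, with an expected range of 480 nM to 2300 nM.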

Compound 4, half-maximal inhibitory concentration: > 5000 nM
Compound 4: no number, only a limit; the forecaster's own chance of this, stated with the estimate: 3%; at least 4.7-fold (0.67 log units) between middle value and limit.
By their numbers in this assay, from the lowest: compound 2; then compounds 3 and 1 (each within the scatter of the next). At a limit, above all of these: compound 4.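

In this assay, 5-fluoro-1H-indol-3-yl in place of 4-fluoro-1H-indol-3-yl gives an at least 4.0-fold higher number from compound 1 to compound 4 (0.61 log units; beyond the scatter), so this shift of the fluoro on the indolyl group, with the atoms otherwise unchanged, is not neutral. Among these compounds, the only earlier step concerned a fluoro elsewhere in the molecule and gave a 1.3-fold lower number from compound 1 to compound 3 (0.10 log units; within the scatter), which said nothing about the indolyl group; the series is therefore sensitive to where the fluoro sits on the indolyl group, even though the fluoro at the other place can go without a change beyond the scatter. For compound 4 the assay gives only a limit, > 5000 nM, so the step above fixes a minimum size and not the full size: the limit of > 5000 nM in this assay, at which 1 of the 4 values shown sits.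

The compounds shown do not tell whether 4-fluoro-1H-indol-3-yl is itself favourable or 5-fluoro-1H-indol-3-yl is unfavourable, and an unsubstituted indolyl group, or a chloro or a methoxy group in place of the fluoro, would separate those two readings. Going by these compounds, whether the same shift has the same effect on the core of compound 3, which has hydrogen in place of the other fluoro, also stays open.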